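From Methyl to Chloro: A Small Step Expected

The compounds below may be only part of what the source reports. "The series", "measured", "known", "first", "only" and "open" are said of these compounds alone.

In a functional assay on A-431 cells (Homo sapiens) for antiproliferative activity, read by sulforhodamine B assay, with a stated time of 72 h (on this read-out higher numbers stand for weaker inhibition and lower numbers for stronger inhibition), compound 1 `C=C1CC(CBr)(c2ccc(C)cc2)OC1=O` gives 2200 nM as its half-maximal inhibitory concentration. Compound 2 `C=C1CC(CBr)(c2ccccc2OC)OC1=O` gives 2400 nM and compound 3 `C=C1CC(CBr)(c2ccccc2F)OC1=O` gives 1700 nM on the same read-out. These three numbers all lie within the usual scatter of one another, so compound 1 stands level with both of the others.

Not yet measured, compound 4 `C=C1CC(CBr)(c2ccc(Cl)cc2)OC1=O` differs from compound 1 by a single change chloro in place of methyl on an aromatic carbon with chloro in place of methyl on an aromatic carbon, para to a group of 9 heavy atoms. For the measured compounds named here, no measured pair makes this exact swap. The closest evidence is another swap of one group on an aromatic carbon, fluoro in place of methoxy, which gives a 1.4-fold lower number from compound 2 to compound 3 (0.15 log units; within the scatter) and stays within the scatter. Across compound 1, compound 2 and compound 3 the groups on the aromatic ring differ, yet the numbers remain within the scatter.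

No step beyond the scatter is therefore expected in this assay and neither direction can be favoured. The expected step is a 1.1-fold lower number from compound 1 to compound 4 (0.04 log units; within the scatter) and it stays within the scatter. Compound 4 is estimated at 2000 nM with 1100 nM to 3600 nM as its expected range.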

Compound 4, half-maximal inhibitory concentration: 1100 nM
The estimate for compound 4 lay 1.8-fold (0.26 log units) above the measured number; the range from low to high includes it.
By their numbers in this assay, from the lowest: compounds 4, 3, 1 and 2 (each within the scatter of the next, the first and the last beyond it).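

For the compounds shown here, this is the first direct reading of a swap at this one place, on an aromatic carbon, para to a group of 9 heavy atoms: in this assay, chloro in place of methyl gives a 2.0-fold lower number from compound 1 to compound 4 (0.30 log units; within the scatter) and nothing else in the molecule changes. The earlier step, fluoro in place of methoxy, involved a different pair of groups, so only this result shows that one heavy atom can be exchanged for another here without a step beyond the scatter, and compound 1 and compound 4 therefore stand level. No independent measurement is available that could explain how these two groups behave at this place.

The compounds shown cover only methyl and chloro at this place, both small groups of a single heavy atom, so they do not show how far that tolerance extends. As far as these compounds go, an amine, a carboxylic acid or a longer chain such as propyl on the same carbon could still give a step beyond the scatter in either direction, and the same swap on the shared core at another ring carbon also remains open.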